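Swapping the carboxyphenyl end group in a glutamate receptor modulator

The source may report more compounds than this note shows. Statements on the series, on what has been measured and on what is new or still open speak of the compounds shown alone.

Measured so far:
- compound 1, `Cc1c(OCCCCOc2ccccc2C(=O)O)ccc(C(=O)CC2CCCC2)c1C`: 67.1%
- compound 2, `Cc1c(OCCCCOc2ccc(C(=O)O)cc2F)ccc(C(=O)CC2CCCC2)c1O`: 83.8%

In an assay on HEK293 cells for positive allosteric modulation of metabotropic glutamate receptor 2 (Rattus norvegicus), read by thallium flux, with a stated time of 2.5 min (a lower number here means a smaller maximal response, a higher number a larger maximal response), compound 2 gives 83.8%, the higher of the two numbers recorded. Compound 1 gives 67.1% in this assay, a lower maximal response that lies beyond the usual scatter of this measurement. Among the measured compounds shown here, compound 2 and compound 1 differ in more than one place, so no single step between them can be read off.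

Compound 3, `Cc1c(OCCCCOc2ccccc2C(=O)O)ccc(C(=O)CC2CCCC2)c1O`, has not yet been measured. It is reached from compound 2 by one change: 2-carboxyphenyl in place of 4-carboxy-2-fluorophenyl on an oxygen on a saturated carbon. For the measured compounds named here, no measured pair shows this exact change, so the size of the step is open.

Because compound 2 reaches 83.8% while compound 1 sits at 67.1%, the step from compound 2 to compound 3 is expected to be downward and of modest size, a number 11.8 percentage points lower from compound 2 to compound 3 (beyond the scatter). Compound 3 is therefore estimated to give 72% in this assay, within a range of 55% to 90%.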

Compound 3, largest response reached (reported as percent of maximum), in percent of the reference or control that the assay uses: 98.8%
For compound 3 the middle estimate is 26.8 percentage points below the measured one, and the stated range ends below it.
By their numbers in this assay, from the lowest: compound 1; then compound 2; then compound 3.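

In this assay the end group on the chain matters: 2-carboxyphenyl in place of 4-carboxy-2-fluorophenyl gives a number 15 percentage points higher from compound 2 to compound 3 (beyond the scatter) and so raises the maximal response. Hydroxy in place of methyl on an aromatic carbon gives a number 31.7 percentage points higher from compound 1 to compound 3 (beyond the scatter) and is a large step, so the response depends on this second place as well. Nothing available here explains why either change acts as it does. The compounds shown leave open how much of the first step comes from losing the fluorine and how much from the changed place of the carboxylic acid, a question that a 4-carboxyphenyl end group would help to separate. They also leave open whether an amine or a methoxy group on that aromatic carbon would keep the response that hydroxy gives.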